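Cyanoguanidine histamine H2 antagonists: triazole in place of pyrimidine

The source may report more compounds than this note shows. Statements on the series, on what has been measured and on what is new or still open speak of the compounds shown alone.

compound 1 `CN/C(=N/C#N)NCCCCc1c[nH]c(C)n1` — < 5
compound 2 `N#C/N=C(\NCCNc1ccnc(N)n1)NCCSc1ccccc1` — < 5

Two compounds have been run in a functional assay on Sf9 cells for antagonist activity at histamine H2 receptor (Homo sapiens), read by scintillation counting and GTPgammaS binding, with a stated time of 90 min; on this read-out higher numbers stand for higher potency (the scale is a negative logarithm) and lower numbers for lower potency. Compound 1 `CN/C(=N/C#N)NCCCCc1c[nH]c(C)n1` gives only a limit of the assay, < 5. Compound 2 `N#C/N=C(\NCCNc1ccnc(N)n1)NCCSc1ccccc1` likewise gives only a limit, < 5. Compound 2 thus stands where every value shown so far stands, as the limit of < 5 in this assay, at which 2 of the 2 values shown sit, records. For the measured compounds named here, no step between measured compounds is available to lean on.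

Compound 3 `N#C/N=C(\NCCCNc1nc(N)n[nH]1)NCCSc1ccccc1` differs from compound 2 by ((3-amino-1H-1,2,4-triazol-5-yl)amino)methyl in place of (2-aminopyrimidin-4-yl)amino on a saturated chain carbon, two bonds along the chain from an amine nitrogen; the rest of the molecule is unchanged. Going by the values given here, with no measured step to set a size or a direction, no change beyond the usual scatter is expected from this exchange; the expected step is a number no lower from compound 2 to compound 3 (the limit leaves the size open). Compound 3 is accordingly estimated at 5, in a range from 4.4 to 5.7, with a real chance that this assay once more returns only a limit rather than a number.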

Compound 3, negative logarithm of the antagonist equilibrium constant: < 5
Compound 3: only a limit was reported; the forecaster's own chance of this, stated with the estimate: 60%; the middle value lies on the limit itself.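

In this assay, for the compounds shown here, compound 3, like compound 2, returns only a limit, so no step between the two can be read: the limit of < 5 in this assay, at which 3 of the 3 values shown sit. The compounds shown leave open whether exchanging (2-aminopyrimidin-4-yl)amino for ((3-amino-1H-1,2,4-triazol-5-yl)amino)methyl alters potency at all.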